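From Fluorophenyl to Methylphenyl: What to Expect of Compound 4

A few compounds are considered here, and "the series" means these few. Any claim that something is new, unique, unknown or untested is made for them only; others in the source may bear on it.

Compound 3 `CNC(=O)c1cc(Oc2ccc(NC(=O)c3nn(-c4cccc(F)c4)c(=O)cc3C)cc2F)ccn1` gives 6410 nM in a functional assay on MCF7 cells (Homo sapiens) for cytotoxicity, read by MTT assay, with a stated time of 72 h (a higher number here means a weaker inhibitor, a lower number a stronger inhibitor), the lowest of the two numbers shown. Compound 1 `CNC(=O)c1cc(Oc2ccc(NC(=O)c3nn(-c4ccccc4C(F)(F)F)c(=O)cc3C)cc2F)ccn1` gives 35700 nM, so that the change to compound 3 is a 5.6-fold lower number from compound 1 to compound 3 (0.75 log units; beyond the scatter). Compound 2 `CNC(=O)c1cc(Oc2ccc(NC(=O)c3nn(-c4ccccc4OC(F)(F)F)c(=O)cc3C)cc2F)ccn1` reaches only a limit in this assay, > 40000 nM, and the limit of > 40000 nM in this assay, at which 1 of the 3 values shown sits, applies to it alone; the step to compound 3 is an at least 6.2-fold lower number from compound 2 to compound 3 (0.79 log units; beyond the scatter). Compound 4 `CNC(=O)c1cc(Oc2ccc(NC(=O)c3nn(-c4ccc(C)cc4)c(=O)cc3C)cc2F)ccn1` differs from compound 3 by 4-methylphenyl in place of 3-fluorophenyl on an aromatic nitrogen. Both measured steps removed a 2-(trifluoromethyl)phenyl or a 2-(trifluoromethoxy)phenyl for 3-fluorophenyl; neither tests an exchange of fluorine for methyl, so they bear on this step only loosely, and a change of at most modest size, most likely toward a weaker inhibitor, is expected: a 1.4-fold higher number from compound 3 to compound 4 (0.15 log units; within the scatter). Compound 4 is thus estimated at 9000 nM, with a range from 3000 nM to 30000 nM.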

Compound 4, half-maximal inhibitory concentration: 8380 nM
Beside the measured number, compound 4's estimate is 1.1-fold (0.03 log units) above it; low and high end bracket the measured number.
By their numbers in this assay, from the lowest: compounds 3 and 4 (each within the scatter of the next); then compound 1. At a limit, above all of these: compound 2.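

In this assay, 4-methylphenyl on the aromatic nitrogen takes the place of 3-fluorophenyl with no change beyond the scatter (a 1.3-fold higher number from compound 3 to compound 4 (0.12 log units; within the scatter)). The lower numbers seen with 3-fluorophenyl thus hold for a second group, set against 2-(trifluoromethyl)phenyl (a 4.3-fold lower number from compound 1 to compound 4 (0.63 log units; beyond the scatter)) and 2-(trifluoromethoxy)phenyl (an at least 4.7-fold lower number from compound 2 to compound 4 (0.67 log units; beyond the scatter)). Compound 2 stands at a limit, not a number: the limit of > 40000 nM in this assay, at which 1 of the 4 values shown sits.

Since the group and its ring position change together here, the compounds shown do not separate the two. They leave open how 4-fluorophenyl, 3-methylphenyl or a phenyl carrying an amine or a carboxylic acid would compare.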